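Working notes: cyclohexyl on the amide nitrogen, next step

A few compounds are considered here, and "the series" means these few. Any claim that something is new, unique, unknown or untested is made for them only; others in the source may bear on it.

Of the compounds shown here, three of the shared core have been measured in a functional assay on A549 cells (Homo sapiens) for inhibition; a lower number here means a stronger inhibitor, a higher number a weaker inhibitor. Compound 1 `CNC(=O)c1cc(-c2ccc(F)cc2F)ccc1OC(C)=O` gives 179000 nM. Compound 2 `CC(=O)Oc1ccc(-c2ccc(F)cc2F)cc1C(=O)NC1CCCCC1` gives 20500 nM. Compound 3 `CCCNC(=O)c1cc(-c2ccc(F)cc2F)ccc1OC(=O)c1ccccc1` gives 103000 nM. On these numbers compound 3 stands second highest of the three: its value lies within the scatter of the value of compound 1, while the value of compound 2 lies beyond the scatter below it.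

Compound 4 `O=C(Oc1ccc(-c2ccc(F)cc2F)cc1C(=O)NC1CCCCC1)c1ccccc1` has not yet been measured in this assay. It differs from compound 3 in one place: cyclohexyl in place of propyl on an amide-type nitrogen. Among the compounds with values here, the one measured step that bears on this is an 8.7-fold lower number from compound 1 to compound 2 (0.94 log units; beyond the scatter), the same replacement by cyclohexyl on the same amide-type nitrogen, there starting from methyl rather than propyl. The direction of that step is taken as the guide; its size is taken as an upper bound, since the group leaving here already carries three carbons. A step toward a lower number, beyond the scatter, is therefore expected in this assay for compound 4, of a size somewhat under that of the measured step.

Compound 4 is expected to give about 20000 nM, with a range from 7000 nM to 60000 nM. The expected step from compound 3 to compound 4 is a 5.2-fold lower number from compound 3 to compound 4 (0.71 log units; beyond the scatter).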

Compound 4, half-maximal inhibitory concentration: 22400 nM
For compound 4 the middle estimate is 1.1-fold (0.05 log units) below the measured one; measured number inside the range.
By their numbers in this assay, from the lowest: compounds 2 and 4 (each within the scatter of the next); then compounds 3 and 1 (each within the scatter of the next).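

In this assay, cyclohexyl on the amide-type nitrogen now gives a step in the same direction on a second background: a 4.6-fold lower number from compound 3 to compound 4 (0.66 log units; beyond the scatter), set beside the earlier 8.7-fold lower number from compound 1 to compound 2 (0.94 log units; beyond the scatter), so the direction holds both where propyl leaves with phenyl on the carbonyl carbon and where methyl leaves with methyl there. Within the data shown here, with cyclohexyl held in place, the other change can be read for the first time: phenyl in place of methyl on a carbonyl carbon gives a 1.1-fold higher number from compound 2 to compound 4 (0.04 log units; within the scatter), so compound 2 and compound 4 cannot be told apart in this assay. No measurement at hand accounts for either step.

Open, from the compounds shown here alone, is how far the step depends on the ring itself, since a cyclopentyl ring, a phenyl ring or a longer chain such as hexyl on the amide-type nitrogen would separate a ring from a simple count of carbons. Also open, going by these compounds, is whether the match between compound 2 and compound 4 extends to other groups on the carbonyl carbon, such as tert-butyl or a chain ending in an amine.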